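The compounds below may be only part of what the source reports. "The series", "measured", "known", "first", "only" and "open" are said of these compounds alone.

Working notes on the series in a functional assay on HepG2 cells (Homo sapiens) for inhibition, read by MTT assay, with a stated time of 48 h; a lower number here means a stronger inhibitor, a higher number a weaker inhibitor.

Three compounds of this set have numbers. Compound 1 `O=C(Nc1cnn(-c2ccccc2)c1)c1cccc(NS(=O)(=O)c2ccccc2)c1` gives 10100 nM in this assay. Compound 2 `COc1ccc(-n2cc(NC(=O)c3cccc(NS(=O)(=O)c4ccc(Cl)cc4)c3)cn2)cc1` gives 15200 nM. Compound 3 `O=C(Nc1cnn(-c2ccccc2)c1)c1ccc(NS(=O)(=O)c2ccccc2)cc1` gives 21500 nM, the highest of the three numbers; the gap to compound 2 is within the scatter, so the two cannot be ordered, whereas compound 1 sits at a lower number than compound 3 by a margin beyond the scatter. The whole set thus lies in a narrow, weak band in this assay.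

Compound 4 `COc1cccc(-n2cc(NC(=O)c3ccc(NS(=O)(=O)c4ccccc4)cc3)cn2)c1` has not been measured. It differs from compound 3 in one place: methoxy in place of hydrogen on an aromatic carbon. Among the compounds with values here, no measured pair in this set isolates this same change, so no step can be read from the data for it. Compound 2 also carries a methoxy on that ring together with other differences, and its number lies within the scatter of compound 3; this gives no sign of a large shift in either direction. The step from compound 3 to compound 4 is expected to be a 1.1-fold lower number from compound 3 to compound 4 (0.03 log units; within the scatter), that is, none beyond the scatter. Compound 4 is therefore estimated at 20000 nM in this assay, with a range from 8000 nM to 50000 nM.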

Compound 4, half-maximal inhibitory concentration: 64200 nM
Beside the measured number, compound 4's estimate is 3.2-fold (0.51 log units) below it, and the stated range ends below it.
By their numbers in this assay, from the lowest: compounds 1, 2 and 3 (each within the scatter of the next, the first and the last beyond it); then compound 4.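

In this assay, within the data shown here, the change from phenyl to 3-methoxyphenyl gives a 3.0-fold higher number from compound 3 to compound 4 (0.48 log units; beyond the scatter) and is the first step in this set that isolates a single difference. It shows that this position on the ring, meta to a large group, is not indifferent to substitution: methoxy in place of hydrogen moves the number upward by a margin beyond the scatter, in a series that already sits in a weak band. The data at hand hold no measurement that accounts for this step.

Open, going by these compounds, is whether the upward shift belongs to methoxy in particular or to any group on this carbon, which a fluorine atom, a hydroxyl group, an amine or a carboxylic acid at the same place would help to separate. Equally open, on these data alone, is whether the step seen on the core of compound 3 carries over to the core of compound 1, since a single pair on one core cannot establish a trend for the series.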